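Removing the nitro group from compound 1: an expectation

The source may hold more compounds than are shown below. What is called first, only, known or untested is meant among the compounds shown, and "the series" means these compounds.

Three compounds have been measured in a functional assay on CRL2813 cells (Homo sapiens) for cytotoxicity, read by sulforhodamine B assay, with a stated time of 5 days; a higher number here means a weaker inhibitor, a lower number a stronger inhibitor:

compound 1 `O=C(Nc1cccc([N+](=O)[O-])c1)N[C@H]1CC[C@H](Oc2ccc(F)cc2)CC1`: 6700 nM
compound 2 `O=C(Nc1cccc(C(F)(F)F)c1)N[C@H]1CC[C@H](Oc2ccc(Cl)cc2)CC1`: 2000 nM
compound 3 `O=C(Nc1ccc(F)cc1)N[C@H]1CC[C@H](Oc2ccc(F)cc2)CC1`: 20000 nM

Compound 1 stands second highest of these three numbers. Compound 2 gives a lower number, and compound 3 a higher one, the latter by a 3.0-fold higher number from compound 1 to compound 3 (0.47 log units; beyond the scatter). Compound 4 `O=C(Nc1ccccc1)N[C@H]1CC[C@H](Oc2ccc(F)cc2)CC1` differs from compound 1 by hydrogen in place of nitro on an aromatic carbon. Among the compounds with values here, only one measured step bears on this change: a 3.0-fold higher number from compound 1 to compound 3 (0.47 log units; beyond the scatter), which also replaced the 3-nitrophenyl group, though by 4-fluorophenyl rather than phenyl. Within the data shown here, no step isolates the nitro group alone, so the expectation is uncertain. Compound 4 is expected to move in the same direction, by a 1.8-fold higher number from compound 1 to compound 4 (0.25 log units; within the scatter). The estimate for compound 4 is therefore 12000 nM, in a range from 5000 nM to 30000 nM.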

Compound 4, half-maximal inhibitory concentration: 20000 nM
Compound 4: the middle estimate sits 1.7-fold (0.22 log units) below what was measured; measured number inside the range.
By their numbers in this assay, from the lowest: compound 2; then compound 1; then compounds 3 and 4 (each within the scatter of the next).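

Within the data shown here, with the nitro group gone and nothing put in its place, the change alone gives a 3.0-fold higher number from compound 1 to compound 4 (0.47 log units; beyond the scatter) in this assay, a step the earlier compounds could only approach through a replacement that also brought in fluoro. Hydrogen in place of fluoro then gives no change at the digits printed from compound 3 to compound 4 (within the scatter), so in this series that fluoro makes no visible difference, and the rise seen with compound 3 is matched by losing the nitro group alone. Nothing available explains this step.

On these data alone, whether an amine or a nitrile at this place would match compound 1 remains open. So does whether the nitro group itself matters or any group there would do.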